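Ethynyl in Place of Bromo: Expecting Compound 4

A few compounds are considered here, and "the series" means these few. Any claim that something is new, unique, unknown or untested is made for them only; others in the source may bear on it.

The three measured compounds share one core, seen in compound 1 `O=C(Nc1cc(F)ccc1F)c1cc(=O)[nH]c2cc(Br)ccc12`, compound 2 `O=C(Nc1cccc(F)c1)c1cc(=O)[nH]c2cc(Br)ccc12` and compound 3 `COc1cccc(NC(=O)c2cc(=O)[nH]c3cc(Br)ccc23)c1`. In a functional assay on KYSE-70 cells for antiproliferative activity against KYSE-70 cell line (Homo sapiens), read by MTT assay, with a stated time of 72 h (on this read-out lower numbers stand for stronger inhibition and higher numbers for weaker inhibition), compound 1 reaches only a limit, > 20000 nM. Compound 2 gives 8900 nM. Compound 3 likewise reaches only a limit, > 20000 nM. For the measured compounds named here, compound 2 thus stands as the only numeric value in the set, the other two being limits (the limit of > 20000 nM in this assay, at which 2 of the 3 values shown sit). The measured steps, an at least 2.2-fold lower number from compound 1 to compound 2 (0.35 log units; beyond the scatter) and an at least 2.2-fold higher number from compound 2 to compound 3 (0.35 log units; beyond the scatter), both concern the fluoro or methoxy of the amide aryl group, not the bromo of compound 2. Compound 4 `C#Cc1ccc2c(C(=O)Nc3cccc(F)c3)cc(=O)[nH]c2c1` differs from compound 2 in the following way: ethynyl in place of bromo on an aromatic carbon. Going by the values given here, no measured step touches this place, so the data give no direction for it, and a change beyond the scatter is not expected in either sense. Compound 4 is estimated at 8000 nM, with a range from 3000 nM to 25000 nM. The expected step of a 1.1-fold lower number from compound 2 to compound 4 (0.05 log units; within the scatter) lies within the scatter.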

Compound 4, half-maximal inhibitory concentration: 9500 nM
The estimate for compound 4 lay 1.2-fold (0.07 log units) below the measured number, and the stated range covers the measured number.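

In this assay, the change on an aromatic carbon, meta to a fused ring and para to a fused ring, gives a 1.1-fold higher number from compound 2 to compound 4 (0.03 log units; within the scatter). For the compounds shown here, this is the first reading at this position, since the earlier steps concerned only the amide aryl group. On this single pair, ethynyl, with its two heavy atoms and triple bond, can stand in place of the single bromine atom without a change beyond the scatter, and neither compound ranks above the other.

Going by these compounds, whether an amine, a carboxylic acid or a longer chain would be tolerated at this position stays open. Also open is how ethynyl would fare with the amide aryl groups of compound 1 and compound 3, whose values are limits and not numbers: the limit of > 20000 nM in this assay, at which 2 of the 4 values shown sit.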